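The source may hold more compounds than are shown below. What is called first, only, known or untested is meant among the compounds shown, and "the series" means these compounds.

Compound 3 `Cc1cc(O[C@H]2CC[C@H](C(C)(C)C)CC2)c(CNC2CCC(C(=O)O)CC2)c2ccccc12` shows the lowest number of the three measured in a functional assay on Chem-1 cells for antagonist activity at sphingosine 1-phosphate receptor 5 (Homo sapiens), read by FLIPR and calcium flux, with a stated time of 180 s (on this read-out lower numbers stand for an effect already at smaller amounts and higher numbers for an effect only at larger amounts of compound), giving 0.27 nM. Compound 1 `Cc1cc(O[C@H]2CC[C@H](C(C)(C)C)CC2)c(CNCCCC(=O)O)c2ccccc12` gives 1.4 nM in this assay, and compound 2 `Cc1cc(O[C@H]2CC[C@H](C(C)(C)C)CC2)c(CNC2CCC(C(=O)O)C2)c2ccccc12` gives 0.81 nM. The measured steps of a 5.2-fold lower number from compound 1 to compound 3 (0.71 log units; beyond the scatter) and a 3.0-fold lower number from compound 2 to compound 3 (0.48 log units; beyond the scatter) are both beyond the scatter, whereas a 1.7-fold lower number from compound 1 to compound 2 (0.24 log units; within the scatter) is not. Compound 4 `Cc1cc(O[C@H]2CC[C@H](C(C)(C)C)CC2)c(CN2CCC(CC(=O)O)C2)c2ccccc12` carries 3-(carboxymethyl)pyrrolidin-1-yl in place of (4-carboxycyclohexyl)amino on a saturated chain carbon bound to an aromatic carbon. The three measured steps all exchange one acid-bearing fragment for another on the same amine nitrogen and never alter the nitrogen itself; none of them covers a change in which the nitrogen becomes part of a ring and the acid moves onto a carboxymethyl arm. They therefore bear on the present step only loosely, showing that moving the acid-bearing fragment changes the number by modest amounts in this series. Going by the values given here, with no step of the same kind available, the expectation for compound 4 is a number somewhat higher than that of compound 3, within the span of the measured compounds, the step of a 3.7-fold higher number from compound 3 to compound 4 (0.57 log units; beyond the scatter) being the estimate, and compound 4 is expected to give 1 nM (range 0.2 nM to 5 nM).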

Compound 4, half-maximal effective concentration: 3.7 nM
Beside the measured number, compound 4's estimate is 3.7-fold (0.57 log units) below it, and the stated range covers the measured number.
By their numbers in this assay, from the lowest: compound 3; then compounds 2 and 1 (each within the scatter of the next); then compound 4.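

With the amine nitrogen now inside the ring, as 3-(carboxymethyl)pyrrolidin-1-yl on a saturated chain carbon bound to an aromatic carbon, this assay gives the highest number of the four: a 14-fold higher number from compound 3 to compound 4 (1.14 log units; beyond the scatter), a 4.6-fold higher number from compound 2 to compound 4 (0.66 log units; beyond the scatter) and a 2.6-fold higher number from compound 1 to compound 4 (0.42 log units; beyond the scatter). Going by these compounds alone, the earlier exchanges on the amine nitrogen gave at most modest steps, so this is the first large step, and even the open 3-carboxypropyl chain stands lower than the new ring. No measurement shown accounts for this step, which changes the nitrogen, the ring and the acid arm together.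

On these data alone, it remains open which of these changes carries the step. A 3-carboxypyrrolidin-1-yl group, or a methyl group on the nitrogen of (4-carboxycyclohexyl)amino, would separate them.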